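This account rests on a few compounds, and the source may have more. Where it says the series, first, only, none or still open, it means among the compounds named here.

In a functional assay on NCI-H460 cells (Homo sapiens) for antiproliferative activity, read by MTT assay, with a stated time of 48 h (on this read-out lower numbers stand for stronger inhibition and higher numbers for weaker inhibition), compound 1 `COc1ccc(-c2nc3cccc(-c4cc(OC)c(OC)c(OC)c4)c3o2)cc1` gives 3500 nM. Compound 2 `COc1ccc(-c2nc3cccc(-c4cc(OC)c(OC)c(OC)c4)c3o2)cc1OC` is recorded only as a limit of the assay, > 25000 nM. Compound 3 `COc1cc(-c2cccc3nc(-c4cccc(Cl)c4)oc23)cc(OC)c1OC` is likewise recorded only as a limit, > 25000 nM. Compound 4 `COc1cc(-c2cccc3nc(-c4cccc(N)c4)oc23)cc(OC)c1OC` differs from it by one change: amino in place of chloro on an aromatic carbon. Within the data shown here, no measured step makes this exchange. The nearest are an at least 7.1-fold higher number from compound 1 to compound 3 (0.85 log units; beyond the scatter) and an at least 7.1-fold higher number from compound 1 to compound 2 (0.85 log units; beyond the scatter), both on that same phenyl, while a step that the two limits leave unreadable from compound 2 to compound 3 cannot be sized. A modest move towards a lower number is therefore expected in this assay, though a second limit remains possible. The expected step is an at least 2.0-fold lower number from compound 3 to compound 4 (0.31 log units; beyond the scatter). For compound 4 the estimate is 12000 nM, with an expected range from 2500 nM to 40000 nM.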

Compound 4, half-maximal inhibitory concentration: 2600 nM
The estimate for compound 4 lay 4.6-fold (0.66 log units) above the measured number, and the stated range covers the measured number.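

Among these compounds, on this phenyl, the earlier compounds showed only moves to the limit; here a substituent other than methoxy keeps a measurable value, with an at least 9.6-fold lower number from compound 3 to compound 4 (0.98 log units; beyond the scatter) and an at least 9.6-fold lower number from compound 2 to compound 4 (0.98 log units; beyond the scatter). Against compound 1 there is a 1.3-fold lower number from compound 1 to compound 4 (0.13 log units; within the scatter), so 3-aminophenyl matches 4-methoxyphenyl within the scatter. Compound 3 is recorded only as a limit, and so is compound 2: the limit of > 25000 nM in this assay, at which 2 of the 4 values shown sit.

On these data alone, what remains open is whether the gain is specific to amino. A hydroxyl, an acetamide or a dimethylamine at that same place could still behave differently.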